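Sulfonyl in place of carbamoyl on the shared core

The source may hold more compounds than are shown below. What is called first, only, known or untested is meant among the compounds shown, and "the series" means these compounds.

In a functional assay on DU-145 cells (Homo sapiens) for inhibition, read by trypan blue exclusion, with a stated time of 72 h (on this read-out higher numbers stand for weaker inhibition and lower numbers for stronger inhibition), compound 1 (`Cn1c(=O)c(S(=O)(=O)c2ccc(C(=O)O)cc2)cc2cnc(Nc3ccc4[nH]ccc4c3)nc21`) gives 10000 nM and compound 2 (`Cn1c(=O)c(S(=O)(=O)Cc2ccc(F)cc2F)cc2cnc(Nc3ccc4[nH]ccc4c3)nc21`) gives 1000 nM while compound 3 (`Cn1c(=O)c(C(=O)Nc2ccc(F)cc2)cc2cnc(Nc3ccc4[nH]ccc4c3)nc21`) gives 5000 nM which lies within the scatter of compound 1 and beyond the scatter of compound 2. Compound 4 (`Cn1c(=O)c(S(=O)(=O)c2ccc(Cl)cc2)cc2cnc(Nc3ccc4[nH]ccc4c3)nc21`) has (4-chlorophenyl)sulfonyl in place of (4-fluorophenyl)carbamoyl on an aromatic carbon of the shared core. Within the data shown here, no measured step makes this exchange. The nearest evidence is a 10-fold lower number from compound 1 to compound 2 (1.00 log units; beyond the scatter) which alters only the group on the sulfonyl sulfur, so the sulfonyl link alone fixes no single level. In this assay no step beyond the scatter is expected, the estimate being a 1.7-fold lower number from compound 3 to compound 4 (0.22 log units; within the scatter) at most modestly downward. For compound 4 the estimated value is 3000 nM with an expected range from 800 nM to 10000 nM as its upper end.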

Compound 4, half-maximal inhibitory concentration: 250 nM
Compound 4: the middle estimate sits 12-fold (1.08 log units) above what was measured; the whole stated range lies above it.
By their numbers in this assay, from the lowest: compound 4; then compound 2; then compounds 3 and 1 (each within the scatter of the next).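

In this assay, (4-chlorophenyl)sulfonyl on this aromatic carbon of the shared core gives a far lower number than (4-fluorophenyl)carbamoyl (a 20-fold lower number from compound 3 to compound 4 (1.30 log units; beyond the scatter)). Among the sulfonyl compounds, 4-chlorophenyl on the sulfur improves on 2,4-difluorobenzyl (a 4.0-fold lower number from compound 2 to compound 4 (0.60 log units; beyond the scatter)), and chloro in place of carboxy has a larger effect (a 40-fold lower number from compound 1 to compound 4 (1.60 log units; beyond the scatter)), leaving compound 4 lowest of the four. Nothing measured here explains these steps.

From the compounds shown here alone, the exchange from compound 3 changes link and halogen together, so the contribution of each stays open. A (4-chlorophenyl)carbamoyl group would separate them, while an amine or methoxy group in place of the chloro remains untested ground in what is shown.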